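Removing the Chloro Group from Compound 1

The compounds below may be only part of what the source reports. "The series", "measured", "known", "first", "only" and "open" are said of these compounds alone.

Measured so far:
compound 1 `O=C(Cn1c(=O)oc2cc(Cl)ccc21)Nc1nc2ccccc2s1` — 52.5%
compound 2 `O=C(Cn1c(=O)oc2cc([N+](=O)[O-])ccc21)Nc1ccccn1` — 47.3%
compound 3 `O=C(Cn1c(=O)oc2ccccc21)NCc1ccccn1` — 38.7%

Of the compounds shown here, three have been tested in an ADME assay on RAW264.7 cells (Mus musculus) for cytotoxicity, read by MTT assay, with a stated time of 72 h, tested at 100 uM; on this read-out lower numbers stand for a weaker effect and higher numbers for a stronger effect at the one concentration tested. In this assay compound 1 gives 52.5%, the highest of the three numbers. Compound 2 gives 47.3%, which lies within the scatter of compound 1, so the two cannot be told apart. Compound 3 gives 38.7%, a number that sits beyond the scatter below compound 1. No pair among these three differs in only one place, so no single step can be read directly from them.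

Compound 4 `O=C(Cn1c(=O)oc2ccccc21)Nc1nc2ccccc2s1` has not yet been measured. It differs from compound 1 in one place: hydrogen in place of chloro on an aromatic carbon. Going by the values given here, the chloro group, the only feature of compound 1 that sets it apart from compound 4, is simply dropped. Nothing in the measured set shows what such a removal does on its own, so any expectation rests on the spread of the three numbers.

The expected step from compound 1 to compound 4 in this assay is a number 7.5 percentage points lower from compound 1 to compound 4 (within the scatter), a small move downward that is estimated to stay within the usual scatter. Compound 4 is therefore expected to give about 45%, with a likely range from 32% to 58%.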

Compound 4, a percentage reported as inhibition, at one concentration (the size of the read-out at that concentration, not a potency): 59.6%
Compound 4: middle estimate off by 14.6 percentage points, on the low side; measured number above the stated range.
By their numbers in this assay, from the lowest: compounds 3, 2, 1 and 4 (each within the scatter of the next, the first and the last beyond it).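

In this assay, going by these compounds alone, hydrogen in place of chloro on an aromatic carbon gives a number 7.1 percentage points higher from compound 1 to compound 4 (within the scatter), and this is the first step in the set that isolates a single change. The two compounds cannot be told apart, so the chloro group on this six-membered aromatic ring of carbon only, part of a fused or bridged system of two rings, is not required for the size of the read-out at the one concentration tested; because this is a single reading at one concentration, it says nothing about potency. No measurement at hand explains why the read-out holds when the chloro group is removed.

From the compounds shown here alone, whether a methoxy group, an amine or a carboxylic acid on the same aromatic carbon would also stay within the scatter of compound 4, or would move the number beyond it, remains open. A single pair also leaves open whether removing chloro from this place would give a similar step if the rest of the molecule carried a different group on the amide nitrogen.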